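Removing the allyl group from compound 1: an expectation

The source may report more compounds than this note shows. Statements on the series, on what has been measured and on what is new or still open speak of the compounds shown alone.

In an assay on the whole organism (plasma, strain Sprague-Dawley) for inhibition of Dipeptidyl peptidase 4 (Rattus norvegicus), with a stated time of 6 h, at a dose of 1 mg/kg by the oral route (on this read-out higher numbers stand for more inhibition at the one dose given (going by the name of the read-out) and lower numbers for less inhibition), compound 1, with the structure `C=CC[C@@H]1CN[C@H](C(=O)N2CCC[C@H]2C#N)C1`, gives 38%, the lowest of the three measured numbers. Compound 2 `C[C@@H]1N[C@H](C(=O)N2CCC[C@H]2C#N)C[C@@H]1C(=O)N1CCOCC1` gives 94% and compound 3 `C[C@@H]1N[C@H](C(=O)N2CCC[C@H]2C#N)C[C@@H]1C(=O)N1CCCCC1` gives 91% in this assay; both lie beyond the scatter above compound 1. Going by the values given here, the only measured single-point step, a number 3 percentage points lower from compound 2 to compound 3 (within the scatter), concerns a different place on the shared core and so says nothing about the change to compound 4 `N#C[C@@H]1CCCN1C(=O)[C@@H]1CCCN1`, which is hydrogen in place of allyl on a saturated ring carbon. Among the compounds with values here, with no step bearing on it, no direction beyond the scatter can be supported, and a wide range is appropriate. Compound 4 is therefore estimated at 30% in this assay, within 10% to 55%, an expected step of a number 8 percentage points lower from compound 1 to compound 4 (within the scatter).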

Compound 4, a percentage reported as inhibition, in the whole organism at one dose (the size of the read-out at that dose, not a potency): 20%
Beside the measured number, compound 4's estimate is 10 percentage points above it, within the range that was stated.
By their numbers in this assay, from the lowest: compound 4; then compound 1; then compounds 3 and 2 (each within the scatter of the next).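

Replacing the allyl group with hydrogen on this saturated ring carbon in this assay gives a number 18 percentage points lower from compound 1 to compound 4 (beyond the scatter). Going by these compounds alone, this modest step is the first evidence that what this position carries affects the read-out, and here the allyl group gives the higher number. Nothing measured here explains the drop. On these data alone, whether a saturated propyl chain, a longer chain or an amine at this position would give a higher number remains open. A single step also cannot show whether size, the double bond or something else matters.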